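Hemolysis of benzofuroxan hydrazones: one swap, two cores

The source may hold more compounds than are shown below. What is called first, only, known or untested is meant among the compounds shown, and "the series" means these compounds.

Measured compounds:
compound 1 `[O-][n+]1onc2ccc(COc3ccccc3/C=N\NC(=S)Nc3ccccc3)cc21` — > 200 uM
compound 2 `NC(=O)N/N=C\c1ccccc1OCc1ccc2no[n+]([O-])c2c1` — > 100 uM
compound 3 `CC1(C)[N+]([O-])=c2ccc(COc3ccccc3/C=N\NC(=S)Nc3ccccc3)cc2=[N+]1[O-]` — 66 uM

In an ADME assay on cells (Erythrocyte, Homo sapiens), read by spectrophotometry and hemolysis, with a stated time of 24 h (on this read-out lower numbers stand for stronger inhibition and higher numbers for weaker inhibition), compound 1 reaches only a limit, > 200 uM, a sign that the assay gave no number, as the limit of > 200 uM in this assay, at which 1 of the 3 values shown sits, states. Compound 2 likewise sits at a limit, > 100 uM, as the limit of > 100 uM in this assay, at which 1 of the 3 values shown sits, states. The change between them is a group of 3 heavy atoms (1 carbon, 1 nitrogen, 1 oxygen; no ring) in place of a group of 9 heavy atoms (7 carbon, 1 nitrogen, 1 sulfur; one six-membered aromatic ring of carbon only), on an amine nitrogen, and its size is a step that the two limits leave unreadable from compound 1 to compound 2. Within the data shown here, compound 3 gives the only number, 66 uM; how its core differs from that of compound 1 is not broken down here. Compound 4 `CC1(C)[N+]([O-])=c2ccc(COc3ccccc3/C=N\NC(N)=O)cc2=[N+]1[O-]` carries the same change on the core of compound 3: a group of 3 heavy atoms (1 carbon, 1 nitrogen, 1 oxygen; no ring) in place of a group of 9 heavy atoms (7 carbon, 1 nitrogen, 1 sulfur; one six-membered aromatic ring of carbon only), on an amine nitrogen. Since the earlier step stays unreadable, the step from compound 3 is estimated only loosely as a 2.0-fold higher number from compound 3 to compound 4 (0.29 log units; within the scatter), and compound 4 is expected to give 130 uM, within 50 uM and 300 uM.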

Compound 4, concentration for 50% inhibition: 50 uM
For compound 4 the middle estimate is 2.6-fold (0.41 log units) above the measured one, and the stated range covers the measured number.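

In this assay, putting carbamoyl in place of the ring-bearing group on the amine nitrogen of the core of compound 3 gives a 1.3-fold lower number from compound 3 to compound 4 (0.12 log units; within the scatter), so on this core the swap leaves no readable change. Among these compounds, on the core of compound 1 the same swap cannot be read, because compound 1 and compound 2 both stand at limits rather than numbers, and the limit of compound 1 is printed here: the limit of > 200 uM in this assay, at which 1 of the 4 values shown sits. Carrying the change from one core to the other is therefore neither confirmed nor ruled out, since only one readable step exists.

As far as these compounds go, what an ethyl chain or a carboxylic acid would do in place of carbamoyl stays open on both cores. From the compounds shown here alone, whether any group on this nitrogen can move the number beyond the scatter also stays open.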